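The source may hold more compounds than are shown below. What is called first, only, known or untested is meant among the compounds shown, and "the series" means these compounds.

Compound 1 `CC1(C)[C@H]2CC[C@]1(C)N(Cc1cn(-c3ccccc3)nn1)C(=O)C2` carries a phenyl on an aromatic nitrogen of the shared core. In a functional assay on LoVo cells (Homo sapiens) for inhibition, read by MTT assay, with a stated time of 24 h (on this read-out higher numbers stand for weaker inhibition and lower numbers for stronger inhibition), compound 1 gives 50 nM, the lowest number of the three measured, although both of its companions stand within the scatter of it. Compound 2 `CC1(C)[C@H]2CC[C@]1(C)N(Cc1cn(-c3ccccc3Br)nn1)C(=O)C2` gives 60 nM, and compound 3 `CC1(C)[C@H]2CC[C@]1(C)N(Cc1cn(-c3ccc(Br)cc3)nn1)C(=O)C2` gives 60 nM. The step of a 1.2-fold higher number from compound 1 to compound 2 (0.08 log units; within the scatter) and the step of a 1.2-fold higher number from compound 1 to compound 3 (0.08 log units; within the scatter) both stay within the scatter, as does the step of no change at the digits printed from compound 2 to compound 3 (within the scatter). Compound 4 `CC1(C)[C@H]2CC[C@]1(C)N(Cc1cn(-c3cccc(C#N)c3)nn1)C(=O)C2` has not yet been measured. It differs from compound 1 by cyano in place of hydrogen on an aromatic carbon; read one bond further out, the change is phenyl to 3-cyanophenyl. Within the data shown here, no measured step introduces a cyano group, so the two bromo steps from compound 1 are the nearest guide: each placed a new group on the phenyl and shifted the number only within the scatter. A step of similar size, a 1.1-fold higher number from compound 1 to compound 4 (0.04 log units; within the scatter), is therefore expected. Compound 4 is estimated at 55 nM, with a range from 25 nM to 120 nM.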

Compound 4, half-maximal inhibitory concentration: 320 nM
Beside the measured number, compound 4's estimate is 5.8-fold (0.76 log units) below it; measured number outside the range, above it.
By their numbers in this assay, from the lowest: compounds 1, 2 and 3 (each within the scatter of the next); then compound 4.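

In this assay, the phenyl of compound 1 proves not to be indifferent to every new group: cyano on an aromatic carbon, meta to a large group, gives a 6.4-fold higher number from compound 1 to compound 4 (0.81 log units; beyond the scatter), whereas both bromo steps stayed within the scatter. The gap to the two bromo compounds is similar, with a 5.3-fold higher number from compound 2 to compound 4 (0.73 log units; beyond the scatter) and a 5.3-fold higher number from compound 3 to compound 4 (0.73 log units; beyond the scatter), so compound 4 stands apart from all three earlier compounds. Nothing available here gives a reason for this gap.

The compounds shown leave open whether the shift belongs to the cyano group itself or to its place on the ring: bromo appears only as 2-bromophenyl and 4-bromophenyl, and cyano only as 3-cyanophenyl. From the compounds shown here alone, how an amine or a carboxylic acid at that same place would read also remains open.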